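Cytotoxicity tolerance across three measured compounds and one pending

The source may hold more compounds than are shown below. What is called first, only, known or untested is meant among the compounds shown, and "the series" means these compounds.

Measured so far in an ADME assay on HEL cells (Homo sapiens) for cytotoxicity, with a stated time of 3 days; a higher number here means that more compound is tolerated, a lower number that less compound is tolerated:
- compound 1 `CCC1(Cc2ccccc2)OS(=O)(=O)C=C1OCC(=O)OC` gives > 400000 nM, a limit of the assay.
- compound 2 `CCC1(Cc2ccccc2)OS(=O)(=O)C=C1OCc1ccc(Cl)c(Cl)c1` gives >= 20000 nM, a limit of the assay.
- compound 3 `CCC1(Cc2ccccc2)OS(=O)(=O)C=C1OCc1ccccc1` gives >= 50000 nM, a limit of the assay.

All three values are limits, so no numbered comparison is possible within the series. The step that the two limits leave unreadable from compound 1 to compound 2, the step that the two limits leave unreadable from compound 1 to compound 3 and the step that the two limits leave unreadable from compound 2 to compound 3 are each left unreadable by the two limits involved. Compound 3 stands at the limit of >= 50000 nM in this assay, at which 1 of the 3 values shown sits; compound 1 sits at the limit of > 400000 nM in this assay, at which 1 of the 3 values shown sits, and compound 2 at the limit of >= 20000 nM in this assay, at which 1 of the 3 values shown sits.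

Compound 4 `CCC1(Cc2ccccc2)OS(=O)(=O)C=C1OCc1ccc([N+](=O)[O-])cc1` is the next to be measured in this assay. Its difference from compound 3 is nitro in place of hydrogen on an aromatic carbon. Among the measured compounds shown here, the measured steps that touch the same place, those from compound 1 to compound 3 and from compound 2 to compound 3, show only that swapping the group on the saturated chain carbon bound to an oxygen on an unsaturated carbon left every value at a limit. No readable step size is available, so no change beyond the scatter is expected for the step of a number no higher from compound 3 to compound 4 (the limit leaves the size open). Compound 4 is therefore estimated at 50000 nM, in a range from 15000 nM to 200000 nM, most likely reported again as a limit.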

Compound 4, minimum cytotoxic concentration: >= 80000 nM
Compound 4: only a limit was reported; the forecaster's own chance of this, stated with the estimate: 70%; middle value at least 1.6-fold (0.20 log units) away from the limit.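

In this assay compound 4 gives >= 80000 nM, a limit of the assay. Its steps to compound 1, compound 2 and compound 3 all join two limits, so none can be read. The compounds shown leave open where any of the four actual tolerated concentrations lies, and whether nitro in place of hydrogen changes it at all.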